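Replacing a urea-bearing chain with a piperidinylethyl group

The source may hold more compounds than are shown below. What is called first, only, known or untested is meant among the compounds shown, and "the series" means these compounds.

Compound 1 `NCCCCN(C[C@H]1Cc2nccnc2CN1)[C@H]1CCCc2cccnc21` gives 77% in an ADME assay on microsomes from liver (Mus musculus) for metabolic stability, using NADPH, with a stated time of 10 min; on this read-out higher numbers stand for a more stable compound and lower numbers for a less stable compound.
Compound 2 `NCCCCN(C[C@@H]1Cc2nccnc2CN1)[C@H]1CCCc2cccnc21` gives 73% in this assay.
Compound 3 `NC(=O)NC/C=C\CN(C[C@H]1Cc2ncccc2CN1)[C@H]1CCCc2cccnc21` gives 10% in this assay.

Compound 3 stands lowest of the three numbers, far beneath compound 1 and compound 2. Among the measured compounds shown here, the only step measured between close neighbours, a number 4 percentage points lower from compound 1 to compound 2 (within the scatter), rests on the fact that compounds 1 and 2 differ only in the configuration as drawn and does not touch the chain that is now changed. Compound 4 `c1cnc2c(c1)CN[C@@H](CN(CCCC1CCNCC1)[C@H]1CCCc3cccnc31)C2` differs from compound 3 by a group of 8 heavy atoms (7 carbon, 1 nitrogen; one six-membered non-aromatic ring with 1 hetero atom) in place of a group of 7 heavy atoms (4 carbon, 2 nitrogen, 1 oxygen; no ring), on a saturated chain carbon bound to an amine nitrogen. For the measured compounds named here, no measured step bears on this change, so the direction is uncertain and a wide range is expected. Compound 4 is estimated to reach 45% in this assay, between 15% and 80%. This estimate means a step of a number 35 percentage points higher from compound 3 to compound 4 (beyond the scatter) is expected.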

Compound 4, percent of the compound remaining: 69%
For compound 4 the middle estimate is 24 percentage points below the measured one; low and high end bracket the measured number.
By their numbers in this assay, from the lowest: compound 3; then compounds 4, 2 and 1 (each within the scatter of the next).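

In this assay, the group on a saturated chain carbon bound to an amine nitrogen proves able to move the number far: putting 2-(piperidin-4-yl)ethyl in place of the urea-bearing chain gives a number 59 percentage points higher from compound 3 to compound 4 (beyond the scatter). Among the compounds shown here, this is the only step beyond the scatter between close neighbours here, and nothing at hand accounts for it. Because the whole group changes at once, the compounds leave open which part of it matters, since the ring, the urea and the double bonds all differ together. As far as these compounds go, whether a morpholine ring or a longer chain ending in an amine would behave like 2-(piperidin-4-yl)ethyl also stays open.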